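Replacing chloro with phenoxy on compound 1

A few compounds are considered here, and "the series" means these few. Any claim that something is new, unique, unknown or untested is made for them only; others in the source may bear on it.

Growth inhibition in a functional assay on DU-145 cells (Homo sapiens) for inhibition, read by trypan blue exclusion, with a stated time of 96 h; on this read-out lower numbers stand for stronger inhibition of growth and higher numbers for weaker inhibition of growth:
Compound 1 `O=C(/C(=C\c1ccc(Cl)cc1)SCc1ccccc1Cl)c1ccc(Cl)cc1`: 12000 nM
Compound 2 `O=C(/C(=C\c1ccc(Cl)cc1)Sc1ccc(Cl)cc1)c1ccc(Cl)cc1`: 1000 nM
Compound 3 `O=C(/C(=C\c1ccc(Cl)cc1)SCc1ccc(F)cc1)c1ccc(Cl)cc1`: 10000 nM
Compound 4 `O=C(/C(=C\c1ccc(Oc2ccccc2)cc1)SCc1ccccc1Cl)c1ccc(Cl)cc1`: not yet measured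

Compound 1 shares the high end of these numbers with compound 3 (a 1.2-fold lower number from compound 1 to compound 3 (0.08 log units; within the scatter)), while compound 2 stands apart (a 12-fold lower number from compound 1 to compound 2 (1.08 log units; beyond the scatter)). Compound 4 carries phenoxy in place of chloro on an aromatic carbon, para to a large group (phenoxy in place of chloro on an aromatic carbon). The measured steps bear on this only indirectly. The large ones, such as a 10-fold higher number from compound 2 to compound 3 (1.00 log units; beyond the scatter), are changes on the sulfur, and none touches this carbon. The data therefore give no direction, and no step beyond the scatter is expected in this assay (a 1.2-fold lower number from compound 1 to compound 4 (0.08 log units; within the scatter)). Compound 4 is estimated at 10000 nM (expected range 2500 nM to 35000 nM).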

Compound 4, concentration for 50% growth inhibition: 1000 nM
Compound 4: middle estimate off by 10-fold (1.00 log units), on the high side; measured number below the stated range.
By their numbers in this assay, from the lowest: compounds 2 and 4 (each within the scatter of the next); then compounds 3 and 1 (each within the scatter of the next).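

In this assay, among the compounds shown here, the step of a 12-fold lower number from compound 1 to compound 4 (1.08 log units; beyond the scatter) shows that this aromatic carbon, para to a large group, responds to substitution, whereas the earlier steps beyond the scatter were all changes on the sulfur. Growth inhibition here therefore tolerates, and improves with, the larger phenoxy in place of chloro. Nothing measured here explains the change.

Going by these compounds, whether the oxygen or the added ring carries the effect remains open, as does how a benzyloxy or a dimethylamino group would behave on this carbon. Also open, on these data alone, is whether phenoxy gives a similar step with other groups on the sulfur.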